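Benzoate aryl variation on the shared core: trimethoxy step

The compounds below may be only part of what the source reports. "The series", "measured", "known", "first", "only" and "open" are said of these compounds alone.

Measured so far:
compound 1 `COC(=O)/C(=C\c1ccc(OC(=O)c2ccccc2)cc1)Sc1ccnc2cc(Cl)ccc12` — 30200 nM
compound 2 `COC(=O)/C(=C\c1ccc(OC(=O)c2ccc(OC)cc2OC)cc1)Sc1ccnc2cc(Cl)ccc12` — 7640 nM

In a functional assay on HL-60 cells (Homo sapiens) for cytotoxicity, read by MTT assay, with a stated time of 24 h (on this read-out higher numbers stand for weaker inhibition and lower numbers for stronger inhibition), compound 1 stands highest of the two numbers, with compound 2 the nearest. For the measured compounds named here, the one step recorded so far, a 4.0-fold lower number from compound 1 to compound 2 (0.60 log units; beyond the scatter), comes from 2,4-dimethoxyphenyl in place of phenyl on a carbonyl carbon.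

Compound 3 `COC(=O)/C(=C\c1ccc(OC(=O)c2cc(OC)c(OC)cc2OC)cc1)Sc1ccnc2cc(Cl)ccc12` is not yet measured. It differs from compound 1 by 2,4,5-trimethoxyphenyl in place of phenyl on a carbonyl carbon. The step from compound 1 to compound 2 bears on it directly: that step was modest but beyond the scatter, and the entering group here carries the same two methoxy positions plus one more, so a step of similar size in the same direction is expected, with the third methoxy group an open question on these data. Compound 3 is expected at 7000 nM, with a range of 2500 nM to 20000 nM. This corresponds to an expected step of a 4.3-fold lower number from compound 1 to compound 3 (0.63 log units; beyond the scatter).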

Compound 3, half-maximal inhibitory concentration: 6260 nM
Compound 3: middle estimate off by 1.1-fold (0.05 log units), on the high side; the measured number falls inside the stated range.
By their numbers in this assay, from the lowest: compounds 3 and 2 (each within the scatter of the next); then compound 1.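

In this assay the step away from phenyl on the carbonyl carbon holds with a third methoxy group present, as 2,4,5-trimethoxyphenyl gives a 4.8-fold lower number from compound 1 to compound 3 (0.68 log units; beyond the scatter) and so remains beyond the scatter. The new information lies in the methoxy in place of hydrogen on an aromatic carbon, which gives a 1.2-fold lower number from compound 2 to compound 3 (0.09 log units; within the scatter) and stays within the scatter, so on this read-out the added group shows no separable effect and the two methoxy-bearing esters stand level. No measurement here accounts for either step.

On these data alone, whether a single methoxy group would be enough to carry the step remains open on these compounds. Also open, as far as these compounds go, is whether an ethoxy, a hydroxyl or an amine in place of methoxy would hold the same level in this assay on the shared core.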